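Swapping phenyl for pyridin-2-yl in compound 1

A few compounds are considered here, and "the series" means these few. Any claim that something is new, unique, unknown or untested is made for them only; others in the source may bear on it.

- compound 1 `O=C1COc2ccccc2N1CCCn1cc(-c2ccccc2)nn1` gives 370 nM
- compound 2 `Cc1ccc(-c2cn(CCCN3C(=O)COc4ccccc43)nn2)cc1` gives 4400 nM
- compound 3 `CCCCCCc1cn(CCCN2C(=O)COc3ccccc32)nn1` gives 710 nM

These values come from a functional assay on IMR-32 cells (Homo sapiens) for antiproliferative activity, read by sulforhodamine B assay, with a stated time of 48 h; a lower number here means a stronger inhibitor of growth, a higher number a weaker inhibitor of growth. Compound 1 lies within the scatter of compound 3, and both give clearly lower numbers than compound 2.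

The next compound to be measured is compound 4 `O=C1COc2ccccc2N1CCCn1cc(-c2ccccn2)nn1`. It keeps the core of compound 1 and changes one group: pyridin-2-yl in place of phenyl on an aromatic carbon. In short, this is pyridin-2-yl in place of phenyl on an aromatic carbon.

For the measured compounds named here, three measured steps bear on this change. Methyl in place of hydrogen on an aromatic carbon gave a large step, a 12-fold higher number from compound 1 to compound 2 (1.08 log units; beyond the scatter). Hexyl in place of phenyl gave a 1.9-fold higher number from compound 1 to compound 3 (0.28 log units; within the scatter), and hexyl in place of 4-methylphenyl gave a 6.2-fold lower number from compound 2 to compound 3 (0.79 log units; beyond the scatter). The group can therefore be replaced with little change in one case, while a small edit to it gives a large change in another. None of these steps places a nitrogen in the ring, so the data offer only loose guidance.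

In this assay the estimated step is a 2.2-fold higher number from compound 1 to compound 4 (0.33 log units; beyond the scatter), a modest move toward a higher number. For compound 4 the expected value is 800 nM, with an estimated range of 200 nM to 3500 nM.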

Compound 4, concentration for 50% growth inhibition: 2000 nM
Compound 4: the middle estimate sits 2.5-fold (0.40 log units) below what was measured; the range from low to high includes it.
By their numbers in this assay, from the lowest: compounds 1 and 3 (each within the scatter of the next); then compound 4; then compound 2.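

In this assay, exchanging one ring carbon of the phenyl for nitrogen, which brings in a hydrogen-bond acceptor, gives a 5.4-fold higher number from compound 1 to compound 4 (0.73 log units; beyond the scatter), so this position responds to a change within the aromatic ring itself and not only to a methyl added to it. Both edits of the phenyl ring, the methyl of compound 2 and the ring nitrogen of compound 4, raise the number, although compound 3, with its hexyl chain, goes against any simple rule that the phenyl ring must stay intact, since it lies within the scatter of compound 1. Compound 4 now occupies a middle place in the series, with a 2.8-fold higher number from compound 3 to compound 4 (0.45 log units; beyond the scatter) and a 2.2-fold lower number from compound 2 to compound 4 (0.34 log units; beyond the scatter).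

The compounds shown leave open whether the rise depends on where the nitrogen sits in the ring, a question that pyridin-3-yl and pyridin-4-yl groups would address, and whether a small group such as fluoro or methoxy on the phenyl would also raise the number as methyl does. No measurement here explains why the ring nitrogen changes the result.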